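The source may hold more compounds than are shown below. What is called first, only, known or untested is meant among the compounds shown, and "the series" means these compounds.

Compound 2 `Cn1cc(-c2ccccc2Oc2ccccc2)c2cc(C(=O)NCCCCCC(=O)Nc3ccccc3N)[nH]c2c1=O` gives 70 nM in a functional assay on MV4-11 cells (Homo sapiens) for antiproliferative activity, read by CCK-8 assay, with a stated time of 72 h (a lower number here means a stronger inhibitor, a higher number a weaker inhibitor), and stands at the lowest number of the three measured compounds. Compound 1 `Cn1cc(-c2ccccc2Oc2ccccc2)c2cc(C(=O)NCCCC(=O)NO)[nH]c2c1=O` gives 380 nM in this assay, and compound 3 `COc1ccc(-c2cn(C)c(=O)c3[nH]c(C(=O)NCc4ccc(C(=O)Nc5ccccc5N)cc4)cc23)cc1` gives 320 nM. Going by the values given here, the one measured step that bears on the next change is a 5.4-fold lower number from compound 1 to compound 2 (0.73 log units; beyond the scatter). Compound 4 `Cn1cc(-c2ccccc2Oc2ccccc2)c2cc(C(=O)NCCCCC(=O)NO)[nH]c2c1=O` differs from compound 2 by hydroxycarbamoyl in place of ((2-aminophenyl)carbamoyl)methyl on a saturated chain carbon, four bonds along the chain from an amide-type nitrogen. Among the compounds with values here, this is nearly the reverse of that step, except that the hydroxycarbamoyl sits four bonds along the chain from the amide-type nitrogen rather than three as in compound 1; no measured pair isolates that difference. The number is therefore expected to rise by about the amount it fell between compound 1 and compound 2. Compound 4 is expected at 280 nM, within 110 nM to 700 nM. The expected step is a 4.0-fold higher number from compound 2 to compound 4 (0.60 log units; beyond the scatter).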

Compound 4, half-maximal inhibitory concentration: 180 nM
Estimate against measurement, compound 4: 1.6-fold (0.19 log units) above, within the range that was stated.
By their numbers in this assay, from the lowest: compound 2; then compounds 4, 3 and 1 (each within the scatter of the next, the first and the last beyond it).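

In this assay replacing ((2-aminophenyl)carbamoyl)methyl with hydroxycarbamoyl on this saturated chain carbon gives a 2.6-fold higher number from compound 2 to compound 4 (0.41 log units; beyond the scatter) and so leaves compound 2 with the lower number, even with the hydroxycarbamoyl four bonds along the chain from the amide-type nitrogen. Within the hydroxycarbamoyl compounds, (hydroxycarbamoyl)methyl in place of hydroxycarbamoyl gives a 2.1-fold lower number from compound 1 to compound 4 (0.32 log units; beyond the scatter) as the first measured effect of chain length at this end. No measured evidence bears on the cause of either step.

Going by these compounds, a longer chain ending in hydroxycarbamoyl remains open, so it is unknown whether the number keeps falling with chain length. On these data alone, a carboxylic acid at the chain end also remains open.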